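This account rests on a few compounds, and the source may have more. Where it says the series, first, only, none or still open, it means among the compounds named here.

Of the compounds shown here, two have been tested in a functional assay on HCT-15 cells (Homo sapiens) for antiproliferative activity, read by sulforhodamine B assay (a lower number here means a stronger inhibitor of growth, a higher number a weaker inhibitor of growth), and a third awaits measurement. Compound 1 `COc1cccc(OCCC(C)(C)C)c1C(=O)/C=C/c1ccc(O)cc1` is one of them. For compound 1 this assay reports only a limit, > 30000 nM, and no number. Within the data shown here, compound 2 `O=C(/C=C/c1ccc(O)cc1)c1c(O)cccc1OCCC1CCCC1` is the other, and in this assay compound 2 gives 3310 nM, the only actual number among the two results, since the remaining one rests at the limit of > 30000 nM in this assay, at which 1 of the 2 values shown sits. Compound 3 `CCCCOc1cccc(O)c1C(=O)/C=C/c1ccc(O)cc1` is the untested one; it differs from compound 2 in a single place, a shortening of the chain that hangs from an oxygen on the aromatic ring: ethyl in place of cyclopentyl on a saturated chain carbon, two bonds along the chain from an oxygen on an aromatic ring. Among the measured compounds shown here, no measured step of this kind exists between the two tested compounds, so the size of the effect can only be guessed. Trimming the chain in this way is expected to cost some activity, a step beyond the usual scatter, estimated as a 2.4-fold higher number from compound 2 to compound 3 (0.38 log units; beyond the scatter). Compound 3 is therefore expected to give about 8000 nM, with a likely range from 2500 nM to 25000 nM.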

Compound 3, concentration for 50% growth inhibition: > 30000 nM
Compound 3 gave a limit, no number (the forecaster's own chance of this, stated with the estimate: 15%); middle value at least 3.7-fold (0.57 log units) from the limit.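

In this assay, among these compounds, replacing cyclopentyl with ethyl at this place on the chain is the first change whose size can be read, and it gives an at least 9.0-fold higher number from compound 2 to compound 3 (0.95 log units; beyond the scatter). The far end of this chain therefore matters: with the rest of the structure unchanged, the 2-cyclopentylethoxy group gives a measurable number, while the butoxy group gives only a limit. This change can be given only a lower bound, because compound 3 sits at a limit and has no number: the limit of > 30000 nM in this assay, at which 2 of the 3 values shown sit.

From the compounds shown here alone, it remains open whether the ring itself matters or simply the size of the group, a question that an open-chain pentyl in place of cyclopentyl would help to settle. How a larger cyclohexyl ring, or an amine at the end of the chain, would behave here is also unknown.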